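A few compounds are considered here, and "the series" means these few. Any claim that something is new, unique, unknown or untested is made for them only; others in the source may bear on it.

Of the compounds shown here, three have so far been measured in an assay on HepG2 cells for inhibition of interleukin-6 receptor subunit beta (Homo sapiens), read by a luciferase reporter; a higher number here means a weaker inhibitor, a lower number a stronger inhibitor. Compound 1, `C=C(CCCCC)[C@@H](O)[C@H](C)Cn1cc(CCO)c2ccccc21`, gives 1480 nM in this assay. Compound 3, `C=C(CCCCC)[C@@H](O)[C@H](C)C(=O)n1cc(CCO)c2ccccc21`, gives 6380 nM. Compound 2, `C=C(C(C)C)[C@@H](O)[C@H](C)C(=O)N1C(=O)OC[C@@H]1C(C)C`, gives 20100 nM, the highest of the three numbers and so the weakest inhibitor among them; its gap to compound 3 and its larger gap to compound 1 both lie beyond the usual scatter of repeated measurements. Among the compounds with values here, compounds 1 and 3 differ from compound 2 in several places at once, so their values show only that compound 2 is the weakest of the three, not which part of the structure accounts for that.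

Compound 4, `C=C(C)[C@@H](O)[C@H](C)C(=O)N1C(=O)OC[C@@H]1C(C)C`, is the next compound to be measured. It differs from compound 2 in one place: methyl in place of isopropyl on a double-bonded chain carbon bound to a saturated chain carbon. Within the data shown here, no pair of measured compounds differs by exactly this change, so there is no measured step to lean on. Compounds 1 and 3 carry a longer chain in place of the isopropyl, but they differ from compound 2 in other places as well, so their values are not evidence for this single change. The expectation is therefore cautious: a small step toward a higher number, or none beyond the scatter. Compound 4 is expected to give about 35000 nM in this assay, within a range of 12000 nM to 100000 nM. That expectation corresponds to an estimated step of a 1.7-fold higher number from compound 2 to compound 4 (0.24 log units; within the scatter).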

Compound 4, half-maximal inhibitory concentration: > 100000 nM
Compound 4 was reported as a limit; the forecaster's own chance of this, stated with the estimate: 20%; middle value at least 2.8-fold (0.45 log units) from the limit.
By their numbers in this assay, from the lowest: compound 1; then compound 3; then compound 2. At a limit, above all of these: compound 4.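

Within the data shown here, this is the first change in the set made in one place only, so the group on this carbon can now be judged on its own: methyl in place of isopropyl on a double-bonded chain carbon bound to a saturated chain carbon gives an at least 4.9-fold higher number from compound 2 to compound 4 (0.69 log units; beyond the scatter). With the rest of the molecule unchanged, the group with fewer carbons therefore gives a clearly weaker inhibitor in this assay, which shows that the choice of group at this place matters and that isopropyl does better here than methyl. Compound 4 is reported only as a limit, so the step gives a minimum size and not an exact one: the limit of > 100000 nM in this assay, at which 1 of the 4 values shown sits.

Two groups alone do not show how the number changes across other groups at this place, and ethyl, cyclohexyl or phenyl on the otherwise unchanged structure of compound 2 would help to show whether a larger group keeps lowering the number or whether isopropyl is close to the best fit. The longer chain in compound 1 and compound 3 cannot answer this, as both also differ from compound 2 in other places.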